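The compounds below may be only part of what the source reports. "The series", "measured", "known", "first", "only" and "open" are said of these compounds alone.

Compound 2 `Cc1cc(/C=C/C#N)cc(C)c1Oc1nc(Nc2ccc(N3CCN(S(N)(=O)=O)CC3)cc2)nc2ccsc12` is known so far only through a limit. In an ADME assay on MT4 cells (Homo sapiens) for cytotoxicity, read by MTT assay, with a stated time of 5 days (a lower number here means that less compound is tolerated, a higher number that more compound is tolerated), compound 2 gives > 222000 nM, which is a limit of the assay and not a number. Compound 1 `Cc1cc(/C=C/C#N)cc(C)c1Oc1nc(Nc2ccc(N3CCCC(NS(N)(=O)=O)C3)cc2)nc2ccsc12` also gives only a limit in this assay, namely > 217000 nM. Between the two lies a step that the two limits leave unreadable from compound 1 to compound 2, the change being 4-sulfamoylpiperazin-1-yl in place of 3-(sulfamoylamino)piperidin-1-yl on an aromatic carbon; its size cannot be read, since one value sits at the limit of > 217000 nM in this assay, at which 1 of the 2 values shown sits, and the other at the limit of > 222000 nM in this assay, at which 1 of the 2 values shown sits.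

Compound 3 `Cc1cc(/C=C/C#N)cc(C)c1Oc1nc(Nc2ccc(CN3CCN(S(N)(=O)=O)CC3)cc2)nc2ccsc12` differs from compound 2 by (4-sulfamoylpiperazin-1-yl)methyl in place of 4-sulfamoylpiperazin-1-yl on an aromatic carbon. Among the measured compounds shown here, the only measured step that bears on this change is the one from compound 1 to compound 2, and it is unreadable, so no direction can be taken from it. Compound 3 is therefore expected to sit where compound 2 sits, with a step of a number no higher from compound 2 to compound 3 (the limit leaves the size open) in this assay that is not expected to go beyond the scatter. The estimate for compound 3 in this assay is 220000 nM, with a range from 100000 nM to 450000 nM, most probably again reported only as a limit.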

Compound 3, half-maximal cytotoxic concentration: 145000 nM
The estimate for compound 3 lay 1.5-fold (0.18 log units) above the measured number, within the range that was stated.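

Among the compounds shown here, compound 3 gives the first true number in this assay, so a change at this place, on an aromatic carbon para to a large group, can for the first time be given a direction, which the two limits of the earlier compounds did not allow. Placing (4-sulfamoylpiperazin-1-yl)methyl there in place of 4-sulfamoylpiperazin-1-yl gives an at least 1.5-fold lower number from compound 2 to compound 3 (0.18 log units; that floor lies within the scatter), and placing it there in place of 3-(sulfamoylamino)piperidin-1-yl gives an at least 1.4-fold lower number from compound 1 to compound 3 (0.17 log units; that floor lies within the scatter). Both steps are only floors that stay within the scatter, and their full size cannot be read, because each starts from a limit of the assay and not from a number: the limit of > 217000 nM in this assay, at which 1 of the 3 values shown sits, and the limit of > 222000 nM in this assay, at which 1 of the 3 values shown sits.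

The compounds shown leave open how the number in this assay would respond to a longer chain between the aromatic ring and the piperazine, and whether the 3-(sulfamoylamino)piperidin-1-yl group would behave as the piperazine does when carried on the same methyl link. They also leave open what a primary amine or a carboxylic acid would do at this place in place of the sulfamoyl group.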